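From nitro to methoxy on a shared core

The compounds below may be only part of what the source reports. "The series", "measured", "known", "first", "only" and "open" are said of these compounds alone.

In a functional assay on A2780 cells (Homo sapiens) for cytotoxicity, read by MTT assay, with a stated time of 72 h (a higher number here means a weaker inhibitor of growth, a lower number a stronger inhibitor of growth), compound 3 `N#C/C(=C/c1ccc([N+](=O)[O-])cc1)C(=O)c1ccc[nH]1` gives 19000 nM. Compound 2 `Cc1ccc(/C=C(/C#N)C(=O)c2ccc[nH]2)cc1` gives 19000 nM, level with compound 3. Compound 1 `N#C/C(=C/c1ccc2ccccc2c1)C(=O)c1ccc[nH]1` gives < 10000 nM, which is a limit of the assay and not a number.

Compound 4 `COc1ccc(/C=C(/C#N)C(=O)c2ccc[nH]2)cc1` differs from compound 3 by one change: methoxy in place of nitro on an aromatic carbon. Among the measured compounds shown here, one measured step bears on this swap: no change at the digits printed from compound 2 to compound 3 (within the scatter), where nitro replaced methyl and the reading stayed within the scatter. On that single step, no shift beyond the scatter is expected in this assay, and the expected step is a 1.1-fold lower number from compound 3 to compound 4 (0.05 log units; within the scatter). Compound 4 is estimated at 17000 nM, with an expected range of 7000 nM to 40000 nM.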

Compound 4, concentration for 50% growth inhibition: < 10000 nM
Compound 4: no number, only a limit; the forecaster's own chance of this, stated with the estimate: 15%; middle value at least 1.7-fold (0.23 log units) from the limit.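

Methoxy at this place, para to a large group, gives the first reading that may differ from the earlier methyl and nitro pair: in this assay there is an at least 1.9-fold lower number from compound 3 to compound 4 (0.27 log units; that floor lies within the scatter), and also an at least 1.9-fold lower number from compound 2 to compound 4 (0.27 log units; that floor lies within the scatter). Compound 4 carries a limit of the assay and not a number. Each step is therefore only a floor, and its full size cannot be read because the reading stops at that limit: the limit of < 10000 nM in this assay, at which 2 of the 4 values shown sit.

As far as these compounds go, how much stronger compound 4 may truly be stays open, as does how an amine or a carboxylic acid would read at this place.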